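Aryl changes on the acylhydrazone of the shared core

A few compounds are considered here, and "the series" means these few. Any claim that something is new, unique, unknown or untested is made for them only; others in the source may bear on it.

Compound 3 `COc1ccc(/C=N/NC(=O)Nc2ccc(Oc3ccnc(-c4nncn4CCN(C)C)c3)c(F)c2)c(OC)c1` gives 1680 nM in a functional assay on MKN-45 cells (Homo sapiens) for cytotoxicity, read by MTT assay, with a stated time of 72 h (on this read-out higher numbers stand for weaker inhibition and lower numbers for stronger inhibition), and holds the highest number of the three measured. Compound 1 `CN(C)CCn1cnnc1-c1cc(Oc2ccc(NC(=O)N/N=C/c3ccc(Cl)cc3Cl)cc2F)ccn1` gives 750 nM and compound 2 `CN(C)CCn1cnnc1-c1cc(Oc2ccc(NC(=O)N/N=C/c3c(Cl)cccc3Cl)cc2F)ccn1` gives 160 nM in this assay, with a 2.2-fold higher number from compound 1 to compound 3 (0.35 log units; beyond the scatter) and an 11-fold higher number from compound 2 to compound 3 (1.02 log units; beyond the scatter) marking the gaps to compound 3; a 4.7-fold lower number from compound 1 to compound 2 (0.67 log units; beyond the scatter) shows that the aryl pattern alone moves the number. Compound 4 `CN(C)CCn1cnnc1-c1cc(Oc2ccc(NC(=O)N/N=C/c3ccc(O)c(Br)c3)cc2F)ccn1` carries 3-bromo-4-hydroxyphenyl in place of 2,4-dimethoxyphenyl on a carbon with a double bond to nitrogen. Both measured steps into compound 3 ran upward from halogen-bearing aryls, so the move away from the dimethoxy group toward a bromine-bearing ring is expected to lower the number, by a modest step of a 2.8-fold lower number from compound 3 to compound 4 (0.45 log units; beyond the scatter) in this assay. Compound 4 is estimated at 600 nM, with a range from 200 nM to 2000 nM.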

Compound 4, half-maximal inhibitory concentration: 1860 nM
Estimate against measurement, compound 4: 3.1-fold (0.49 log units) below; low and high end bracket the measured number.
By their numbers in this assay, from the lowest: compound 2; then compound 1; then compounds 3 and 4 (each within the scatter of the next).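

In this assay, 3-bromo-4-hydroxyphenyl and 2,4-dimethoxyphenyl on this carbon cannot be told apart (a 1.1-fold higher number from compound 3 to compound 4 (0.04 log units; within the scatter)). Compound 4 still sits apart from both dichlorophenyl compounds (a 2.5-fold higher number from compound 1 to compound 4 (0.39 log units; beyond the scatter); a 12-fold higher number from compound 2 to compound 4 (1.07 log units; beyond the scatter)). A halogen on this ring therefore does not by itself give the lower numbers: compound 4 carries bromine and goes against that pattern.

As far as these compounds go, whether an aminophenyl or carboxyphenyl ring here would approach compound 2 remains open. Nothing available explains these differences.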